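The source may hold more compounds than are shown below. What is called first, only, known or untested is meant among the compounds shown, and "the series" means these compounds.

Measured so far in a functional assay on MCF7 cells (Homo sapiens) for cytotoxicity, read by MTT assay, with a stated time of 72 h; a higher number here means a weaker inhibitor, a lower number a stronger inhibitor:
- compound 1 `COc1ccc(/C=C/C(=O)Nc2cc3c(Nc4ccc(F)c(Cl)c4)ncnc3cc2OC)cc1`: "not active" (no number reported)
- compound 2 `COc1cc2ncnc(Nc3ccc(F)c(Cl)c3)c2cc1NC(=O)/C=C/c1ccccc1[N+](=O)[O-]`: 36500 nM
- compound 3 `COc1cc2ncnc(Nc3ccc(F)c(Cl)c3)c2cc1NC(=O)/C=C/c1ccc(C#N)cc1`: "not active" (no number reported)

Compound 3 has no single number to stand on, since it is reported only as "not active" (no number reported). Compound 1 is likewise reported without a number, as "not active" (no number reported). Compound 2 alone gives a figure, at 36500 nM, so the series offers just one numerical reference.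

The next compound to be tested is compound 4 `COc1cc(/C=C/C(=O)Nc2cc3c(Nc4ccc(F)c(Cl)c4)ncnc3cc2OC)cc(OC)c1`. The structural change is 3,5-dimethoxyphenyl in place of 4-cyanophenyl on a double-bonded chain carbon bound to a double-bonded chain carbon. A 3,5-dimethoxyphenyl thus takes the place of the 4-cyanophenyl on a double-bonded chain carbon bound to a double-bonded chain carbon.

With no number for compound 3, the size of this step cannot be measured from its starting point. In this assay, no large move towards a stronger inhibitor is expected. Compound 1, which also carries methoxy on the phenyl of this chain, is reported as "not active" (no number reported), and the only figure available is that of compound 2 at 36500 nM. Compound 4 is therefore expected to remain weak, and it may well yield no number at all. If a number is reported, the estimate for compound 4 is 40000 nM, with an expected range of 15000 nM to 100000 nM.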

Compound 4, half-maximal inhibitory concentration: 38500 nM
The estimate for compound 4 lay 1.0-fold (0.02 log units) above the measured number; measured number inside the range.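

In this assay compound 4 gives 38500 nM and so joins compound 2 as a second compound with a number at this position, on a double-bonded chain carbon bound to a double-bonded chain carbon. Exchanging 2-nitrophenyl for 3,5-dimethoxyphenyl gives a 1.1-fold higher number from compound 2 to compound 4 (0.02 log units; within the scatter) and therefore does not separate these two groups, although they share no substituent, while the steps that involve compound 1 or compound 3 cannot be read. No measurement at hand explains why these aryl groups give numbers where 4-cyanophenyl does not.

Going by these compounds, two numbers within the scatter of each other do not show how far this position can move the result, so it remains open whether a dimethylamino group or a carboxylic acid in place of the nitrile would give a number, and what size it would have. On these data alone, it also remains open whether the aromatic ring is needed at all, since a saturated cyclohexyl ring or a longer alkyl chain at this place would test that directly.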